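The compounds below may be only part of what the source reports. "The series", "measured", "known", "first", "only" and "open" are said of these compounds alone.

The measured compounds, each with its value, are:
compound 1, `O=CN(O)C(CCc1ncccn1)CS(=O)(=O)N1CCN(c2ccc(Cl)cn2)CC1`, with < 10000 nM
compound 2, `CCCc1c(OCCCOc2ccc3c(=O)cc(CCC(=O)O)oc3c2CCC)ccc(C(C)=O)c1O`, with < 10000 nM
compound 3, `COc1ccc(Nc2ccn(-c3ccccc3)n2)cc1`, with 23000 nM

In an ADME assay for inhibition of Bile salt export pump (Homo sapiens), read by scintillation counting, with a stated time of 5 min (a higher number here means a weaker inhibitor, a lower number a stronger inhibitor), compound 1 gives < 10000 nM, which is a limit of the assay and not a number. Compound 2 also gives < 10000 nM, again a limit rather than a number. Within the data shown here, compound 3 is the only one with a number, as in this assay compound 3 gives 23000 nM. Compound 1 thus stands at the limit of < 10000 nM in this assay, at which 2 of the 3 values shown sit, and nothing finer than that limit is known about it; it cannot be placed in order against compound 2, and against compound 3 all that can be said is that the two values sit on different sides of the limit.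

The compound not yet measured is compound 4, `O=CN(O)C(CCc1ccccc1)CS(=O)(=O)N1CCN(c2ccc(Cl)cn2)CC1`. It differs from compound 1 in one place: phenyl in place of pyrimidin-2-yl on a saturated chain carbon, three bonds along the chain from an amide-type nitrogen. Among the measured compounds shown here, no step between measured compounds matches this change, so there is nothing to scale an expectation by. The expectation is that the step in this assay from compound 1 to compound 4 is a step that the limit leaves unreadable from compound 1 to compound 4, with no direction beyond the scatter. Compound 4 is therefore estimated at 6000 nM, within a range from 1500 nM to 25000 nM.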

Compound 4, half-maximal inhibitory concentration: < 10000 nM
Compound 4: a limit, no number (the forecaster's own chance of this, stated with the estimate: 55%); the middle value is on the limit's open side.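

In this assay compound 4 gives < 10000 nM, a limit of the assay and not a number. Compound 1 gives < 10000 nM, also a limit, and no step can be read between compound 1 and compound 4. The compounds shown leave open whether phenyl or pyrimidin-2-yl at this place gives the stronger inhibitor, and by how much.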